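The source may hold more compounds than are shown below. What is called first, only, known or untested is meant among the compounds shown, and "the series" means these compounds.

Measured so far:
- compound 1 `CCOc1ccc(-c2ccc3ncn(-c4cc(OC)c(OC)c(OC)c4)c3c2)cc1`: in a functional assay on MCF7 cells (Homo sapiens) for antiproliferative activity, read by MTT assay, with a stated time of 72 h (a lower number here means a stronger inhibitor, a higher number a weaker inhibitor), compound 1 gives 1710 nM
- compound 2 `COc1cc(-n2cnc3ccc(-c4cccc(N)c4)cc32)cc(OC)c1OC`: in this assay compound 2 gives 180 nM

Within the data shown here, of the two numbers, compound 1 holds the higher one; the only other number belongs to compound 2. The step between them is a 9.5-fold lower number from compound 1 to compound 2 (0.98 log units; beyond the scatter).

Compound 3 `COc1cc(-n2cnc3ccc(-c4ccc(Cl)cc4Cl)cc32)cc(OC)c1OC` is not yet measured. It differs from compound 1 in one place: 2,4-dichlorophenyl in place of 4-ethoxyphenyl on an aromatic carbon.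

Among the measured compounds shown here, the single measured step that bears on this change is a 9.5-fold lower number from compound 1 to compound 2 (0.98 log units; beyond the scatter), since it exchanges the same 4-ethoxyphenyl at the same position. That step shows the number can move well beyond the scatter when this group is exchanged. For the measured compounds named here, no measured compound carries a 2,4-dichlorophenyl, or any group with chlorine, at this position, and 3-aminophenyl is not a close match for it, so the size of the step has no direct precedent. The expected outcome is a modest move toward a lower number, with a wide range that also allows no change beyond the scatter: a 1.9-fold lower number from compound 1 to compound 3 (0.28 log units; within the scatter). For compound 3 in this assay the estimate is 900 nM, with a range from 250 nM to 3500 nM.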

Compound 3, half-maximal inhibitory concentration: 5420 nM
Compound 3: middle estimate off by 6.0-fold (0.78 log units), on the low side; the whole stated range lies below it.
By their numbers in this assay, from the lowest: compound 2; then compound 1; then compound 3.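

In this assay, exchange of the aryl group at this aromatic carbon can move the number in either direction: a 9.5-fold lower number from compound 1 to compound 2 (0.98 log units; beyond the scatter) is a move down, whereas a 3.2-fold higher number from compound 1 to compound 3 (0.50 log units; beyond the scatter) is a move up, so replacing 4-ethoxyphenyl does not by itself lower the number. The new compound also widens the span seen at this one position, with a 30-fold higher number from compound 2 to compound 3 (1.48 log units; beyond the scatter) as the largest step among the three compounds, so the choice of aryl group here matters a great deal in this assay. No measurement in hand gives a reason for either direction or for the size of these steps.

Among these compounds, with only three aryl groups, each differing from the others in several features at once, the effect of the two chlorine atoms cannot be separated from the loss of the ethoxy group, nor the effect of the amine from that of its place on the ring. As far as these compounds go, an unsubstituted phenyl and a phenyl with a single chlorine would be the closest reference points, and whether any other group at this carbon can reach or pass the low number of compound 2 remains open.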